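Dropping the sulfonamide from the indane-imidazoline core

The source may hold more compounds than are shown below. What is called first, only, known or untested is meant among the compounds shown, and "the series" means these compounds.

Two compounds of the series carry a measured maximal response. Compound 1 `CCCS(=O)(=O)Nc1cccc2c1CCC2c1ncc[nH]1` gives 54% in a functional assay on CHO cells for agonist activity at Alpha-1A adrenergic receptor (Homo sapiens), read by FLIPR and calcium flux; on this read-out lower numbers stand for smaller maximal responses and higher numbers for larger maximal responses. Compound 2 `CS(=O)(=O)Nc1c(Cl)ccc2c1CCCC2c1ncc[nH]1` gives 61% in this assay; its value and that of compound 1 sit within the usual scatter of each other, so neither can be placed above the other. Compound 3 `c1ccc2c(c1)CCC2c1ncc[nH]1` has not yet been measured in this assay. Relative to compound 1 it differs in one place: hydrogen in place of (propylsulfonyl)amino on an aromatic carbon. For the measured compounds named here, no step between two measured compounds of this kind exists, so the size of the effect cannot be read from the series. The expectation is a modest step in this assay, if any, with a downward lean that stays near the scatter, since the only measured points, compound 1 at 54% and compound 2 at 61%, give no guidance on removing the group altogether. The step expected here is a number 6 percentage points lower from compound 1 to compound 3 (within the scatter). Compound 3 is estimated at 48%, with a range from 25% to 75%.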

Compound 3, largest response reached (Emax), in percent of the reference or control that the assay uses: 54%
The estimate for compound 3 lay 6 percentage points below the measured number; measured number inside the range.
By their numbers in this assay, from the lowest: compounds 1, 3 and 2 (each within the scatter of the next).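

Hydrogen in place of (propylsulfonyl)amino on the aromatic carbon gives no change at the digits printed from compound 1 to compound 3 (within the scatter) in this assay, the only step read so far at this position. The maximal response seen for compound 1 therefore does not require this group, and compound 3, which has no substituent at this place, now serves as the baseline for the position. Nothing measured on these compounds offers an explanation for this result.

As far as these compounds go, it remains open whether any group on this aromatic carbon can move the maximal response beyond the scatter, for example an amine, a carboxylic acid or a longer chain on the sulfonyl. Also open, from the compounds shown here alone, is whether the same replacement by hydrogen gives a similar step on the core of compound 2.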